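Swapping a methylpyridine for a fluoromethylphenyl ring

The compounds below may be only part of what the source reports. "The series", "measured", "known", "first", "only" and "open" are said of these compounds alone.

Compound 3 `CC[C@@H](Nc1c(C#N)c(-c2ccc(-c3ccncc3C)cc2)nc2cnccc12)C(N)=O` is one of three measured compounds that share a core and differ only in the outer aromatic ring. In a physicochemical assay for lipophilicity, read by HPLC, at pH 7.5 (a higher number here means a more lipophilic compound, a lower number a more polar compound), compound 3 gives 2. That places it second highest of the three: compound 1 `CC[C@@H](Nc1c(C#N)c(-c2ccc(-c3cccnc3C)cc2)nc2cnccc12)C(N)=O` gives 1.9, and the two values lie within the scatter of each other, while compound 2 `CC[C@@H](Nc1c(C#N)c(-c2ccc(-c3cccc(Cl)c3F)cc2)nc2cnccc12)C(N)=O` gives 3.1, clearly higher.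

Compound 4 `CC[C@@H](Nc1c(C#N)c(-c2ccc(-c3cccc(C)c3F)cc2)nc2cnccc12)C(N)=O` has not yet been measured. It differs from compound 3 in one place: 2-fluoro-3-methylphenyl in place of 3-methylpyridin-4-yl on an aromatic carbon

Within the data shown here, two measured steps bear on this change. Going a number 1.20 log units higher from compound 1 to compound 2 (beyond the scatter), a nitrogen-containing six-membered ring gave way to a carbon-only ring bearing a fluorine, and going a number 1.10 log units lower from compound 2 to compound 3 (beyond the scatter), the opposite kind of exchange occurred. Both steps were large, well beyond the scatter, and both point the same way: the carbon-only fluorinated ring comes with the higher number. The change from compound 3 to compound 4 is of the same kind, so a large upward step in this assay is expected, with the estimated step being a number 1.00 log units higher from compound 3 to compound 4 (beyond the scatter). Compound 4 is estimated to give 3, with a range from 2.6 to 3.4.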

Compound 4, distribution coefficient: 3
Beside the measured number, compound 4's estimate shows no gap at the digits printed, within the range that was stated.
By their numbers in this assay, from the lowest: compounds 1 and 3 (each within the scatter of the next); then compounds 4 and 2 (each within the scatter of the next).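

In this assay, the higher numbers no longer rest on a single ring carrying chloro, since a second fluorinated carbon-only ring, 2-fluoro-3-methylphenyl, also stands apart from both methylpyridine rings (a number 1.00 log units higher from compound 3 to compound 4 (beyond the scatter); a number 1.10 log units higher from compound 1 to compound 4 (beyond the scatter)). The new comparison lies within the fluorinated ring itself: methyl in place of chloro gives a difference that cannot be told from repeat measurements (a number 0.10 log units lower from compound 2 to compound 4 (within the scatter)), so on this ring this assay does not separate the two groups. Nothing in the data shown explains why the numbers fall as they do.

Each step from a methylpyridine ring to a fluorinated ring changes several things at once, removing the ring nitrogen and adding fluorine, so the compounds shown cannot divide the difference between those two changes; a 3-methylphenyl ring without fluorine would begin to do that. They also leave open how the number would respond if the methyl or chloro on the fluorinated ring gave way to a different kind of group, such as an amine or a carboxylic acid.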